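The source may hold more compounds than are shown below. What is called first, only, known or untested is meant among the compounds shown, and "the series" means these compounds.

Three compounds sharing one core have been measured in a functional assay on HCT-116 cells (Homo sapiens) for antiproliferative activity, read by CCK-8 assay, with a stated time of 72 h; a lower number here means a stronger inhibitor, a higher number a weaker inhibitor

compound 1 `COc1ccc(SCc2ccc(C(=O)Nc3ccccc3N)cc2)cc1` gives 1640 nM
compound 2 `Cc1ccc(SCc2ccc(C(=O)Nc3ccccc3N)cc2)cc1` gives 2630 nM
compound 3 `Nc1ccccc1NC(=O)c1ccc(CSc2ccc(F)cc2)cc1` gives 4010 nM

Compound 3 stands close to its nearest neighbour, with a 1.5-fold higher number from compound 2 to compound 3 (0.18 log units; within the scatter), and further from the other, with a 2.4-fold higher number from compound 1 to compound 3 (0.39 log units; beyond the scatter). The next compound, compound 4 `Nc1ccccc1NC(=O)c1ccc(CSc2ccc(Cl)cc2)cc1`, comes from compound 3 by a single swap, (chloro in place of fluoro on an aromatic carbon), which puts chloro in place of fluoro on an aromatic carbon, para to a large group. Among the compounds with values here, no measured pair makes this exact swap. The nearest guides are the other swaps of one small group on an aromatic carbon, which also include a 1.6-fold higher number from compound 1 to compound 2 (0.21 log units; within the scatter). Within the data shown here, only the step from compound 1 to compound 3 clears the scatter, and it is modest. Read in reverse, it gives a slight lean towards a lower number, so only a small move within the scatter is expected in this assay. The expected step is a 1.4-fold lower number from compound 3 to compound 4 (0.14 log units; within the scatter). For compound 4 the estimated value is 2900 nM, with an expected range from 1500 nM to 5500 nM.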

Compound 4, half-maximal inhibitory concentration: 3750 nM
The estimate for compound 4 lay 1.3-fold (0.11 log units) below the measured number; the measured number falls inside the stated range.
By their numbers in this assay, from the lowest: compounds 1, 2, 4 and 3 (each within the scatter of the next, the first and the last beyond it).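

Chloro in place of fluoro at this position makes little measurable difference in this assay (a 1.1-fold lower number from compound 3 to compound 4 (0.03 log units; within the scatter)), so 4-fluorophenyl and 4-chlorophenyl cannot be told apart here. Chloro in place of methyl also stays within the scatter (a 1.4-fold higher number from compound 2 to compound 4 (0.15 log units; within the scatter)), while chloro in place of methoxy goes modestly beyond it (a 2.3-fold higher number from compound 1 to compound 4 (0.36 log units; beyond the scatter)), so compound 1 now stands apart from two compounds with different halogens, though not from compound 2. No measurement is available to explain these results.

The compounds shown leave open whether a group of another kind at this position, such as an amine, a carboxylic acid or a longer chain, would shift the number further. They also leave open whether bromo would behave like fluoro and chloro.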